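From 3-methoxyphenyl to 2-bromophenyl on the carbonyl

The source may report more compounds than this note shows. Statements on the series, on what has been measured and on what is new or still open speak of the compounds shown alone.

Measured so far in a functional assay on A549 cells (Homo sapiens) for inhibition, read by MTT assay, with a stated time of 24 h (on this read-out higher numbers stand for weaker inhibition of growth and lower numbers for stronger inhibition of growth), are these compounds:
compound 1 `Cn1cc(-c2nc3ccccc3n2C(=O)c2ccccc2Br)c2ccccc21` gives 43200 nM
compound 2 `COc1ccc2c(c1)c(-c1nc3ccccc3n1C(=O)c1ccccc1)cn2C` gives 16700 nM
compound 3 `COc1cccc(C(=O)n2c(-c3cn(C)c4ccc(OC)cc34)nc3ccccc32)c1` gives 4600 nM

Compound 3 has the lowest number of the three, so it inhibits growth most strongly in this small set. Compound 4 `COc1ccc2c(c1)c(-c1nc3ccccc3n1C(=O)c1ccccc1Br)cn2C` keeps the core of compound 3 and changes one place, with 2-bromophenyl in place of 3-methoxyphenyl on a carbonyl carbon as the whole difference.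

Within the data shown here, one measured step bears on this: a 3.6-fold lower number from compound 2 to compound 3 (0.56 log units; beyond the scatter) came with methoxy in place of hydrogen on an aromatic carbon, a modest change beyond the scatter. Compound 4 gives up that 3-methoxyphenyl group, so that modest gain may be lost. Compound 1 [also bearing 2-bromophenyl] has the highest number at 43200 nM but lacks the methoxy that compound 4 carries on its core. Among the measured compounds shown here, no measured step isolates the bromine.

The expected change is a 2.8-fold higher number from compound 3 to compound 4 (0.45 log units; beyond the scatter) toward weaker inhibition of growth. In this assay compound 4 is estimated at 13000 nM with an expected range of 4500 nM to 36000 nM around that middle.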

Compound 4, concentration for 50% growth inhibition: 29500 nM
Beside the measured number, compound 4's estimate is 2.3-fold (0.36 log units) below it; the measured number falls inside the stated range.
By their numbers in this assay, from the lowest: compound 3; then compounds 2, 4 and 1 (each within the scatter of the next, the first and the last beyond it).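

Set against compound 2, the swap on the carbonyl carbon separates two things in this assay. Replacing 3-methoxyphenyl with 2-bromophenyl gives a 6.4-fold higher number from compound 3 to compound 4 (0.81 log units; beyond the scatter), whereas bromo in place of hydrogen on an aromatic carbon gives only a 1.8-fold higher number from compound 2 to compound 4 (0.25 log units; within the scatter), so compound 4 loses the gain seen with the 3-methoxyphenyl group and the bromine adds no change beyond the scatter. Methoxy in place of hydrogen, on the core this time, gives a 1.5-fold lower number from compound 1 to compound 4 (0.17 log units; within the scatter), and this smaller step cannot be told apart from the earlier one: the same change on two cores in this assay, a 3.6-fold lower number (0.56 log units; beyond the scatter) from compound 2 to compound 3 and a 1.5-fold lower number (0.17 log units; within the scatter) from compound 1 to compound 4, 2.5-fold (0.39 log units) apart, within the scatter of two such steps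

Going by these compounds, it remains open whether any group other than methoxy on this phenyl ring, such as an amine or a carboxylic acid, would match or exceed compound 3. The compounds shown also leave open what a methoxy and a bromine together on this ring would do.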